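Series notes: benzamide-linked purines, antiproliferative read-out

A few compounds are considered here, and "the series" means these few. Any claim that something is new, unique, unknown or untested is made for them only; others in the source may bear on it.

Among the compounds with values here, compound 1 `Cc1ccc(Nc2nc(Cl)nc3c2ncn3Cc2ccc(C(=O)Nc3ccccc3N)cc2)cc1` gives the strongest result of the three measured members: in a functional assay on HepG2 cells (Homo sapiens) for antiproliferative activity, read by CCK-8 assay, with a stated time of 72 h, tested at 2 uM (a lower number here means a weaker effect, a higher number a stronger effect of the compound at the concentration tested), compound 1 gives 76.2%. Compound 3 `Nc1ccccc1NC(=O)/C=C/c1ccc(Cn2cnc3c(Nc4cccc(OC(F)(F)F)c4)nc(Cl)nc32)cc1` gives 16.2% in this assay, and compound 2 `Nc1ccccc1NC(=O)/C=C/c1ccc(COCNc2nc(Nc3cccc(Cl)c3)c3ncn(C4CCCC4)c3n2)cc1` gives 9.67% in this assay; both sit far below compound 1, beyond the scatter, but each differs from compound 1 in several places at once, so no single step can be read from them.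

Compound 4 `Nc1ccccc1NC(=O)c1ccc(Cn2cnc3c(Nc4ccc(-c5ccccn5)cc4)nc(Cl)nc32)cc1` has not been measured. Relative to compound 1 the difference is pyridin-2-yl in place of methyl on an aromatic carbon, the group now standing on an aromatic carbon of a six-membered aromatic ring of carbon only. Within the data shown here, no measured pair shows what such an exchange does here. The core, the benzamide and the chloro group of compound 1 are kept, so a step in this assay of modest size, if any, is expected, more likely downward than upward but plausibly within the scatter. On that basis compound 4 is expected to give 62% in this assay, with a range of 30% to 85%, meaning an estimated step of a number 14.2 percentage points lower from compound 1 to compound 4 (beyond the scatter).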

Compound 4, a percentage reported as inhibition, at one concentration (the size of the read-out at that concentration, not a potency): 11.5%
Beside the measured number, compound 4's estimate is 50.5 percentage points above it, outside the stated range (below it).
By their numbers in this assay, from the lowest: compounds 2, 4 and 3 (each within the scatter of the next); then compound 1.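

Within the data shown here, compound 4 supplies the first single-place step: in this assay, pyridin-2-yl in place of methyl on an aromatic carbon, para to a large group, gives a number 64.7 percentage points lower from compound 1 to compound 4 (beyond the scatter). The read-out at this position therefore depends strongly on the group it carries, with the core, the benzamide and the chloro group unchanged, and 4-(pyridin-2-yl)phenyl does not keep the level seen with 4-methylphenyl. The data at hand offer no measurement that accounts for this step.

One exchange cannot separate the contribution of the added ring from that of its ring nitrogen, so a plain phenyl at the same carbon would be the informative neighbour. On these data alone, whether a methoxy group, an ethyl group or a dimethylamino group there stays nearer compound 1 or nearer compound 4 remains open.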